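This account rests on a few compounds, and the source may have more. Where it says the series, first, only, none or still open, it means among the compounds named here.

Measured so far:
- compound 1 `O=C(Nc1ncc(Cc2ccc(Cl)cc2)s1)c1cccs1` — > 50000 nM (a limit of the assay)
- compound 2 `COCCc1ccc(OC(c2ccc(Cl)cc2)c2cnc(NC(=O)OC(C)(C)C)s2)cc1` — > 50000 nM (a limit of the assay)
- compound 3 `Clc1ccc(C(Oc2ccc3cc(Br)ccc3c2)c2cnc(NCC3CCOCC3)s2)cc1` — "not toxic" (no number reported) (no number reported)

All three were examined in an ADME assay on HepG2 2.2.15 cells (Homo sapiens) for cytotoxicity; a higher number here means that more compound is tolerated, a lower number that less compound is tolerated. Compound 1 gives > 50000 nM, which is a limit of the assay rather than a number. Compound 2 likewise gives > 50000 nM, again a limit. Compound 3 is reported only as "not toxic" (no number reported), so no single number places it among the others; what can be said is that the two further values shown sit at the limit of > 50000 nM in this assay, at which 2 of the 3 values shown sit, and compound 3 is described in the same spirit, as tolerated without a measurable toxic concentration.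

Compound 4 `O=C(Nc1ncc(C(Oc2ccc3cc(Br)ccc3c2)c2ccc(Cl)cc2)s1)c1ccc(Cl)nc1` differs from compound 3 in a single place: (6-chloropyridin-3-yl)carbonyl in place of (oxan-4-yl)methyl on a nitrogen on an aromatic ring

Going by the values given here, no step between measured compounds exists here, so there is nothing to compare this change against. With every value shown at a limit or without a number, the expectation in this assay is no step beyond the scatter in either direction, and the most likely outcome is once more a limit rather than a number. Compound 4 is therefore estimated at 50000 nM, within a range from 20000 nM to 100000 nM.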

Compound 4, half-maximal cytotoxic concentration: "not toxic" (no number reported)
No number was reported for compound 4; the estimate stays without a comparison.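

Compound 3 and compound 4 are both reported only as "not toxic", without a number, so no step can be read between them. The compounds shown leave open at what concentration, if any, each would harm the cells in this assay, as the only figure they offer is a limit: the limit of > 50000 nM in this assay, at which 2 of the 4 values shown sit.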